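Working notes: from compound 3 to compound 4

This account rests on a few compounds, and the source may have more. Where it says the series, first, only, none or still open, it means among the compounds named here.

Compound 3 `COc1cc(C(c2ccc(O)c(OC)c2)[C@@H](CO)C(C)C)ccc1O` is the weak end of what has been measured so far in a functional assay on HL-60 cells (Homo sapiens) for cytotoxicity, read by WST assay, with a stated time of 48 h; a lower number here means a stronger inhibitor, a higher number a weaker inhibitor. Compound 3 reads > 100000 nM, which is a limit of the assay and not a number.

Compound 4 `COc1cc(C(c2ccc(O)c(OC)c2)[C@@H](C)[C@H](C)CF)ccc1O` has not yet been measured. It arises from compound 3 by a single change: 2-(fluoromethyl)-1-methylpropyl in place of 1-(hydroxymethyl)-2-methylpropyl on a saturated chain carbon bound to two aromatic carbons. In words, 2-(fluoromethyl)-1-methylpropyl replaces 1-(hydroxymethyl)-2-methylpropyl on a saturated chain carbon bound to two aromatic carbons.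

The closest guide is compound 1 `COc1cc(C(c2ccc(O)c(OC)c2)[C@@H](C)[C@@H](C)CF)ccc1O`, which carries a group of the same name with a different stereo arrangement and gives 38000 nM. The step of an at least 2.6-fold higher number from compound 1 to compound 3 (0.42 log units; beyond the scatter) exchanges the same two groups, in the opposite direction to the one planned here, and lies beyond the scatter. Compound 2 `COC[C@H](C)[C@@H](C)C(c1ccc(O)c(OC)c1)c1ccc(O)c(OC)c1` gives 68000 nM. The steps of a 1.8-fold higher number from compound 1 to compound 2 (0.25 log units; within the scatter) and an at least 1.4-fold higher number from compound 2 to compound 3 (0.16 log units; that floor lies within the scatter) are told as within the scatter and add little. Since compound 1 differs from compound 4 in its stereo arrangement, its value carries over only loosely.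

A modest gain is expected, with an estimated at least 2.0-fold lower number from compound 3 to compound 4 (0.30 log units; that floor lies within the scatter). For compound 4 the expected value is 50000 nM, with an estimated range of 20000 nM to 100000 nM.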

Compound 4, half-maximal inhibitory concentration: 32000 nM
Compound 4: middle estimate off by 1.6-fold (0.19 log units), on the high side, and the stated range covers the measured number.
By their numbers in this assay, from the lowest: compounds 4, 1 and 2 (each within the scatter of the next, the first and the last beyond it). At a limit, above all of these: compound 3.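

Working from this assay, the result shows that the drawn configuration at this chain stereocentre makes no readable difference here, with a 1.2-fold lower number from compound 1 to compound 4 (0.07 log units; within the scatter), and the two compounds carry the same group: the fact that compounds 1 and 4 differ only in the configuration as drawn

The new compound also gives a readable step against the methoxymethyl chain, a 2.1-fold lower number from compound 2 to compound 4 (0.33 log units; beyond the scatter), where compound 1 stayed within the scatter of compound 2; this is a narrow margin, and the two fluoromethyl compounds themselves cannot be told apart. Against the hydroxymethyl chain, an at least 3.1-fold lower number from compound 3 to compound 4 (0.49 log units; beyond the scatter) gives only a floor, and the limit belongs to compound 3: the limit of > 100000 nM in this assay, at which 1 of the 4 values shown sits.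

The compounds shown leave open whether the hydroxymethyl group or the different branching of its chain sets compound 3 apart, as 1-(hydroxymethyl)-2-methylpropyl differs from the other chains in both respects. Also open, from the compounds shown here alone, is whether an amine or a carboxylic acid on this chain, or a longer chain, would bring the number well below the range seen so far.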